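The source may report more compounds than this note shows. Statements on the series, on what has been measured and on what is new or still open speak of the compounds shown alone.

Measured compounds in this set:

compound 1 `CC[C@H](CCCc1cccnc1)NC(=O)/C=C/C=C(c1ccc(OC)cc1)c1ccc(OC)cc1`: 0.16 mg/kg
compound 2 `COc1ccc(C(=C/C=C/C(=O)N[C@@H](CCCc2cccnc2)C2CC2)c2ccc(OC)cc2)cc1`: 0.2 mg/kg
compound 3 `COc1cccc(C(=C/C=C/C(=O)N[C@H](C)CCCc2cccnc2)c2cccc(OC)c2)c1`: 0.21 mg/kg

In a functional assay with platelet-activating factor receptor (Cavia porcellus) as the target (a higher number here means that more compound is needed for the effect, a lower number that less compound is needed), compound 2 holds the second highest of the three numbers. Its nearest neighbour is compound 3, which differs in more than one place, so only the two values can be compared: they sit within the scatter of each other. Its furthest neighbour is compound 1, and the one-point step there, a 1.3-fold higher number from compound 1 to compound 2 (0.10 log units; within the scatter), is also within the scatter.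

Compound 4 `COc1ccc(C(=C/C=C/C(=O)NCCCCc2cccnc2)c2ccc(OC)cc2)cc1` is not yet measured. Against compound 2 the change is hydrogen in place of cyclopropyl on a saturated chain carbon bound to an amide-type nitrogen and a saturated chain carbon. Among the measured compounds shown here, the only measured step at this position is a 1.3-fold higher number from compound 1 to compound 2 (0.10 log units; within the scatter), a swap of one small carbon group for another with no effect beyond the scatter. Compound 3 carries methyl at the same carbon and gives a value near compound 2, though its other differences blur that reading. Removing the group entirely, to hydrogen, goes further than any measured swap at this carbon, so the step is expected to be small but the uncertainty is wider than the scatter alone. Compound 4 is therefore expected to give about 0.3 mg/kg, in the range 0.12 mg/kg to 0.8 mg/kg, corresponding to an expected step of a 1.5-fold higher number from compound 2 to compound 4 (0.18 log units; within the scatter).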

Compound 4, dose for 50% inhibition: 0.25 mg/kg
Compound 4: the middle estimate sits 1.2-fold (0.08 log units) above what was measured; measured number inside the range.
By their numbers in this assay, from the lowest: compounds 1, 2, 3 and 4 (each within the scatter of the next).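

In this assay, removing the carbon group altogether gives a 1.3-fold higher number from compound 2 to compound 4 (0.10 log units; within the scatter) for the loss of cyclopropyl and a 1.6-fold higher number from compound 1 to compound 4 (0.19 log units; within the scatter) for the loss of ethyl, with both steps inside the scatter. The earlier one-place step at this saturated chain carbon only exchanged one small carbon group for another, whereas hydrogen now gives a reading at the smallest end of the substituents, and hydrogen, ethyl and cyclopropyl cannot be told apart in compound 4, compound 1 and compound 2. Within these compounds, then, holding the number in this assay does not depend on a carbon group at this position, while compound 3 differs in more than one place and gives no clean reading on this point.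

Still open is whether this tolerance extends to a phenyl group, a longer alkyl chain, an amine or a carboxylic acid at the same carbon, since the substituents shown stop at cyclopropyl. No available data address why the number holds across hydrogen, ethyl and cyclopropyl.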